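The compounds below may be only part of what the source reports. "The series", "measured", "known", "first", "only" and "open" are said of these compounds alone.

Measured compounds:
compound 1 `O=[N+]([O-])c1ccc2[nH]c(CN3CCN(c4ccc(F)cc4)CC3)nc2c1` gives 22000 nM
compound 2 `O=[N+]([O-])c1ccc2[nH]c(CNc3c([N+](=O)[O-])ccc4ncccc34)nc2c1` gives 265000 nM

In a functional assay on HepG2 cells (Homo sapiens) for cytotoxicity, read by MTT assay (a higher number here means a weaker inhibitor, a lower number a stronger inhibitor), compound 1 gives 22000 nM, while compound 2 gives 265000 nM. Of these two values compound 2 has the higher one, and the distance between compound 1 and compound 2 lies beyond the usual scatter of this assay, so compound 2 is the weaker of the pair on the numbers seen here.

The next compound, compound 3 `O=[N+]([O-])c1ccc2ncccc2c1NCc1nc2ccccc2[nH]1`, differs from compound 2 in one place: hydrogen in place of nitro on an aromatic carbon. Within the data shown here, no comparable step between two measured compounds exists, so the size and direction of the change in this assay can only be guessed. Given that compound 2 already sits at the weak end, the expectation is a step of modest size, possibly none beyond the scatter, with the outcome for compound 3 estimated as a 1.3-fold lower number from compound 2 to compound 3 (0.12 log units; within the scatter). Compound 3 is therefore expected to give about 200000 nM, within a range from 60000 nM to 700000 nM.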

Compound 3, half-maximal inhibitory concentration: 259000 nM
Beside the measured number, compound 3's estimate is 1.3-fold (0.11 log units) below it; measured number inside the range.
By their numbers in this assay, from the lowest: compound 1; then compounds 3 and 2 (each within the scatter of the next).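

In this assay, among these compounds, hydrogen in place of nitro on an aromatic carbon of the six-membered ring of carbon only gives a 1.0-fold lower number from compound 2 to compound 3 (0.01 log units; within the scatter) as the first step that can be read between two measured compounds. The step lies within the scatter, so in this pair the nitro group at this position can be lost with no readable change in the number. The data shown offer nothing that would explain this result.

As far as these compounds go, it remains open whether another group on this carbon, such as an amine, a methoxy group or a carboxylic acid, would leave the number where it is or shift it beyond the scatter. A single pair also cannot show whether the same exchange would behave alike on a different core.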